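Compound 3 to Compound 4: a Change at the Carbonyl

A few compounds are considered here, and "the series" means these few. Any claim that something is new, unique, unknown or untested is made for them only; others in the source may bear on it.

Of the compounds shown here, three sharing one core have been measured in a functional assay on SW-620 cells (Homo sapiens) for inhibition, read by sulforhodamine B assay, with a stated time of 48 h; on this read-out higher numbers stand for lower toxicity in this test and lower numbers for higher toxicity in this test. Compound 1 `COc1cc(-c2nn(-c3cccc(NC(=O)Nc4ccc(Cl)c(Cl)c4)c3)cc2-c2ccncc2)ccc1Cl` stops at the limit of the test; in this assay compound 1 gives > 50000 nM, which is a limit and not a number. Compound 2 `COc1cc(-c2nn(-c3cccc(NC(=O)Nc4cccc(C(F)(F)F)c4)c3)cc2-c2ccncc2)ccc1Cl` does give a number: in this assay compound 2 gives 50000 nM. Compound 3 `COc1cc(-c2nn(-c3cccc(NC(=O)Nc4ccc(Cl)c(C(F)(F)F)c4)c3)cc2-c2ccncc2)ccc1Cl` again stops at a limit, and in this assay compound 3 gives > 32500 nM. Where compound 3 stands among the three is therefore not fixed: all three values sit at or near the top of the measured range, and the steps of a number no higher from compound 1 to compound 2 (the limit leaves the size open), a step that the two limits leave unreadable from compound 1 to compound 3 and a step that the limit leaves unreadable from compound 2 to compound 3 are each too hemmed in by limits to be sized. Compound 4 `COc1cc(-c2nn(-c3cccc(NC(=O)c4ccccc4)c3)cc2-c2ccncc2)ccc1Cl` differs from compound 3 by phenyl in place of (4-chloro-3-(trifluoromethyl)phenyl)amino on a carbonyl carbon. For the measured compounds named here, no measured step touches this part of the molecule, so none bears directly on it; the three measured values say only that this core shows little toxicity in this assay. The expectation for compound 4 is therefore a value of about 40000 nM, between 10000 nM and 100000 nM, with a good chance that a limit is reported again. This expectation corresponds to an estimated step that the limit leaves unreadable from compound 3 to compound 4, not beyond the scatter.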

Compound 4, concentration lethal to 50% of the cells: > 100000 nM
Compound 4: no number, only a limit; the forecaster's own chance of this, stated with the estimate: 60%; middle value at least 2.5-fold (0.39 log units) away from the limit.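

In this assay compound 4 gives > 100000 nM, which is a limit and not a number. Of the new steps only one can be read, an at least 2.0-fold higher number from compound 2 to compound 4 (0.30 log units; that floor lies within the scatter), while the steps from the two compounds that also stop at limits cannot be read. For the compounds shown here, what the earlier compounds could not show is that this carbonyl position accepts a much smaller change of kind: phenyl can stand in place of (3-(trifluoromethyl)phenyl)amino, losing the amino nitrogen and its hydrogen-bond donor, with no sign of greater toxicity in this test.

Because compound 4 carries no number, the compounds shown leave open how far its true value lies from the others, and the printed limit is all there is to go on: the limit of > 100000 nM in this assay, at which 1 of the 4 values shown sits. It also stays open whether a different group on the carbonyl carbon, such as a simple dimethylamino group or a longer alkyl chain, would keep toxicity this low in this assay or would at last give a value that can be compared.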